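Ester chain lengthening from compound 3 to compound 4

This account rests on a few compounds, and the source may have more. Where it says the series, first, only, none or still open, it means among the compounds named here.

Of the compounds shown here, three sharing one core have been measured in an ADME assay (liver) for pharmacokinetics, with Liver microsome (Rattus norvegicus) as the target, using microsomes; on this read-out higher numbers stand for a longer-lived compound and lower numbers for a shorter-lived compound. Compound 1 `CCOc1cc(NC(=O)C2(NC(=O)c3ccc4c(C5CCCC5)c(-c5ncc(Cl)cn5)n(C)c4c3)CCC2)ccc1/C=C/C(=O)OC(=O)C[C@H](O)C(=O)O` carries a carboxy-hydroxyethylcarbonyl ester and in this assay compound 1 gives 7.92 h. Compound 2 `CCOc1cc(NC(=O)C2(NC(=O)c3ccc4c(C5CCCC5)c(-c5ncc(Cl)cn5)n(C)c4c3)CCC2)ccc1/C=C/C(=O)OCOP(=O)(O)OC(C)(C)C` bears a phosphate-containing ester, and compound 2 gives 0.133 h. Compound 3 `CCOc1cc(NC(=O)C2(NC(=O)c3ccc4c(C5CCCC5)c(-c5ncc(Cl)cn5)n(C)c4c3)CCC2)ccc1/C=C/C(=O)OCC(C)C`, the isobutyl ester, gives 1.42 h, which places compound 3 second of the three: compound 1 stands higher, compound 2 lower.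

The measured steps both concern the ester portion. The step of a 5.6-fold lower number from compound 1 to compound 3 (0.75 log units; beyond the scatter) was modest, and the step of an 11-fold higher number from compound 2 to compound 3 (1.03 log units; beyond the scatter) was large; the step of a 60-fold lower number from compound 1 to compound 2 (1.77 log units; beyond the scatter) was the largest of all. Compound 4 `CCCCCCOC(=O)/C=C/c1ccc(NC(=O)C2(NC(=O)c3ccc4c(C5CCCC5)c(-c5ncc(Cl)cn5)n(C)c4c3)CCC2)cc1OCC` differs from compound 3 by pentyl in place of isopropyl on a saturated chain carbon bound to an oxygen next to a carbonyl group. No measured step exchanges one plain alkyl ester for another; the steps shown swap groups rich in oxygen for a short alkyl chain or for one another, so they bear on the change only loosely. Lengthening an alkyl chain is a smaller change than any of those, and the step from compound 3 to compound 4 in this assay is therefore expected to stay within the scatter, a 1.2-fold lower number from compound 3 to compound 4 (0.07 log units; within the scatter). Compound 4 is estimated at 1.2 h, with a range from 0.45 h to 3.2 h.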

Compound 4, half-life: 12.7 h
For compound 4 the middle estimate is 11-fold (1.02 log units) below the measured one; the measured number lies above the stated range.
By their numbers in this assay, from the lowest: compound 2; then compound 3; then compounds 1 and 4 (each within the scatter of the next).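

In this assay the exchange of one plain alkyl ester for another, pentyl in place of isopropyl on a saturated chain carbon bound to an oxygen next to a carbonyl group, gives a step beyond the scatter (an 8.9-fold higher number from compound 3 to compound 4 (0.95 log units; beyond the scatter)), so a change confined to the all-carbon chain can by itself move this read-out at this position. The hexyl ester also stands level with the (2-carboxy-2-hydroxyethyl)carbonyl ester (a 1.6-fold higher number from compound 1 to compound 4 (0.21 log units; within the scatter)), which shows that this read-out does not separate these two very different groups on the same oxygen. The gap to the phosphate-containing ester widens as well (a 95-fold higher number from compound 2 to compound 4 (1.98 log units; beyond the scatter)), and it is the largest step among the four compounds. Nothing shown here accounts for the size of the step from isobutyl to hexyl.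

The compounds shown leave open whether the change follows chain length or the loss of the branch, a question that a straight butyl ester or a branched 4-methylpentyl ester would address. They also leave open whether a longer chain such as octyl would continue the rise or reverse it.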